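The source may hold more compounds than are shown below. What is called first, only, known or untested is meant among the compounds shown, and "the series" means these compounds.

Compound 1 `Cn1cc(-c2ccccc2NCC2=NCCN2)cn1`: < 100000 nM
Compound 2 `Cn1cccc1-c1ccccc1NCC1=NCCN1`: < 100000 nM

In an in vitro functional assay on cells (Fibroblast) for agonist activity at Alpha-1B adrenergic receptor (Homo sapiens) (a lower number here means that less compound is needed, a higher number that more compound is needed for the effect), compound 1 gives only < 100000 nM, which is a limit of the assay and not a number. Compound 2 likewise gives only < 100000 nM, also a limit. Compound 2 therefore stands at that limit, as the limit of < 100000 nM in this assay, at which 2 of the 2 values shown sit, shows. The step that the two limits leave unreadable from compound 1 to compound 2 cannot be read from two limits. Compound 3 `Cn1ccnc1-c1ccccc1NCC1=NCCN1` differs from compound 2 by 1-methyl-1H-imidazol-2-yl in place of 1-methyl-1H-pyrrol-2-yl on an aromatic carbon. Within the data shown here, no measured step bears on this change, and with compound 2 known only as a limit, the expected step that the limit leaves unreadable from compound 2 to compound 3 rests on very little. Compound 3 is estimated at 10000 nM, within the range 1000 nM to 100000 nM.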

Compound 3, half-maximal effective concentration: 39.8 nM
Beside the measured number, compound 3's estimate is 250-fold (2.40 log units) above it; the measured number lies below the stated range.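

The steps from compound 1 and from compound 2 to compound 3 cannot be read, since compounds 1 and 2 are known only as limits: the limit of < 100000 nM in this assay, at which 2 of the 3 values shown sit.

The compounds shown leave open what actual values compounds 1 and 2 have, and so how large a change 1-methyl-1H-imidazol-2-yl brings.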